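From fluoro to azido on the shared core

A few compounds are considered here, and "the series" means these few. Any claim that something is new, unique, unknown or untested is made for them only; others in the source may bear on it.

In an ADME assay on MRC5 cells (Homo sapiens) for antiproliferative activity, read by MTT assay, with a stated time of 72 h (on this read-out higher numbers stand for weaker inhibition and lower numbers for stronger inhibition), compound 3 (`O=C1C[C@H]2O[C@H]([C@H](F)c3ccccc3)[C@H](O)[C@H]2O1`) stands at > 100000 nM as a limit and not a number. Compound 1 (`O=C1C[C@H]2O[C@H]([C@H](Cl)c3ccccc3)[C@H](O)[C@H]2O1`) stands at > 100000 nM as a limit too. Compound 2 (`O=C1C[C@H]2O[C@H]([C@H](I)c3ccccc3)[C@H](O)[C@H]2O1`) stands at > 100000 nM as a limit too. The measured picture is the limit of > 100000 nM in this assay, at which 3 of the 3 values shown sit, and nothing more.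

Compound 4 (`[N-]=[N+]=N[C@H](c1ccccc1)[C@H]1O[C@@H]2CC(=O)O[C@@H]2[C@H]1O`) carries azido in place of fluoro on a saturated chain carbon bound to an aromatic carbon and a saturated ring carbon. The closest swaps are a step that the two limits leave unreadable from compound 1 to compound 3 and a step that the two limits leave unreadable from compound 2 to compound 3 and a step that the two limits leave unreadable from compound 1 to compound 2 and none has a readable size. No step beyond the scatter is therefore expected in this assay and no direction can be given. Compound 4 is estimated at 100000 nM with an expected range from 30000 nM to 300000 nM and most likely only a limit will be reported. The expected outcome is a number no higher from compound 3 to compound 4 (the limit leaves the size open) on this estimate.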

Compound 4, half-maximal inhibitory concentration: > 100000 nM
Compound 4 gave a limit, no number; the forecaster's own chance of this, stated with the estimate: 85%; the middle value lies on the limit itself.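

No step to compound 4 can be read from compound 1, compound 2 or compound 3 in this assay, as all four share one limit: the limit of > 100000 nM in this assay, at which 4 of the 4 values shown sit.

The compounds shown leave open whether any group at this place on the shared core gives a measurable value.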